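The source may hold more compounds than are shown below. What is called first, only, known or untested is meant among the compounds shown, and "the series" means these compounds.

Compound 1 `C[C@@H](NC(=O)c1ccc(C#Cc2cccnc2)cn1)C(C)(C)O`: in an ADME assay on HEK293 cells for agonist activity at metabotropic glutamate receptor 5 (Rattus norvegicus), read by fluorescence and calcium flux (a lower number here means a smaller maximal response, a higher number a larger maximal response), compound 1 gives 25.9%.
Compound 2 `C[C@@H](NC(=O)c1nc(C#Cc2cccc(F)c2)cs1)C(C)(C)O`: in this assay compound 2 gives 26.1%.
Compound 3 `C[C@H](NC(=O)c1ccc(C#Cc2cccc(F)c2)cn1)C(C)(C)C`: in this assay compound 3 gives 20%.

Compound 3 has the lowest of the three numbers, yet its distances to compound 1 and to compound 2 both lie within the usual scatter, so the three measured compounds cannot be told apart on these numbers. Among the measured compounds shown here, no step between two measured compounds that differ in a single place is known, so nothing measured shows how a single change moves the read-out.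

Compound 4 `CC(C)[C@H](C)NC(=O)c1ccc(C#Cc2cccc(F)c2)cn1` has not yet been measured. It differs from compound 3 in one place: hydrogen in place of methyl on a saturated chain carbon bound to three saturated chain carbons. Because compound 3 gives 20% and both other measured compounds sit within the scatter of that number, compound 4 is expected to stay in the same region, with a step that does not go beyond the scatter in either direction. The estimate for compound 4 is 22%. Compound 4 is expected to fall between 12% and 32%. The expected step is a number 2 percentage points higher from compound 3 to compound 4 (within the scatter).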

Compound 4, largest response reached (reported as efficacy), in percent of the reference or control that the assay uses: 13.1%
Beside the measured number, compound 4's estimate is 8.9 percentage points above it, and the stated range covers the measured number.
By their numbers in this assay, from the lowest: compounds 4, 3, 1 and 2 (each within the scatter of the next, the first and the last beyond it).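

Among the compounds shown here, this is the first comparison in which only one place changes. In this assay, going from tert-butyl to isopropyl gives a step of a number 6.9 percentage points lower from compound 3 to compound 4 (within the scatter) and so cannot be told apart from repeat-measurement noise, which means that on this one pair, hydrogen can stand in place of methyl on this saturated chain carbon without a clear shift in maximal response. No measurement at hand offers an explanation for the size of this step.

Still open, from the compounds shown here alone, is how the read-out responds to other groups on the amide nitrogen, such as a cyclopropyl ring or a longer chain like n-butyl. It is also unknown whether the same swap of methyl for hydrogen would behave alike with the hydroxyl-bearing chain of compound 1 or the core of compound 2.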